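The compounds below may be only part of what the source reports. "The series", "measured", "known", "first", "only" and "open" are said of these compounds alone.

Measured compounds in an assay on a cell-free system (plasma) for inhibition of Dipeptidyl peptidase 4 (Rattus norvegicus), read by fluorescence; on this read-out higher numbers stand for weaker inhibition and lower numbers for stronger inhibition:
Compound 1, `O=C([C@@H]1C[C@H](N2CCN(c3ccccn3)CC2)CN1)N1CCSC1`, gives 3.5 nM.
Compound 2, `O=C([C@@H]1C[C@H](N2CCN(c3ccc(Br)cc3)CC2)CN1)N1CCSC1`, gives 9 nM.
Compound 3, `O=C([C@@H]1C[C@H](N2CCN(c3ccncc3)CC2)CN1)N1CCSC1`, gives 3.9 nM.

Compound 3 stands second highest of the three numbers in this assay. Its nearest neighbour is compound 1, separated by a 1.1-fold higher number from compound 1 to compound 3 (0.05 log units; within the scatter), a gap within the scatter; its furthest is compound 2, separated by a 2.3-fold lower number from compound 2 to compound 3 (0.36 log units; beyond the scatter). Compound 4, `O=C([C@@H]1C[C@H](N2CCN(c3ccc(Cl)cc3)CC2)CN1)N1CCSC1`, has not yet been measured. It differs from compound 3 in one place: 4-chlorophenyl in place of pyridin-4-yl on an amine nitrogen in a ring. The step that bears most directly on this change is a 2.3-fold lower number from compound 2 to compound 3 (0.36 log units; beyond the scatter), in which the 4-bromophenyl ring gave way to pyridin-4-yl; compound 4 reverses that kind of exchange, with a chlorine where compound 2 carries a bromine. The step of a 2.6-fold higher number from compound 1 to compound 2 (0.41 log units; beyond the scatter) points the same way, the 4-bromophenyl ring giving the higher number. Compound 4 is therefore expected to show a modest rise in this assay relative to compound 3, a 2.1-fold higher number from compound 3 to compound 4 (0.31 log units; beyond the scatter). The estimate for compound 4 in this assay is 8 nM, with a range from 4 nM to 16 nM.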

Compound 4, half-maximal inhibitory concentration: 10.3 nM
Compound 4: the middle estimate sits 1.3-fold (0.11 log units) below what was measured; the range from low to high includes it.
By their numbers in this assay, from the lowest: compounds 1 and 3 (each within the scatter of the next); then compounds 2 and 4 (each within the scatter of the next).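

In this assay, chloro in place of bromo on the aromatic carbon leaves the result within the scatter (a 1.1-fold higher number from compound 2 to compound 4 (0.06 log units; within the scatter)), so these two halogens are not told apart at this position. The gap from the pyridine compounds now appears with a second halogen-bearing phenyl group, both against pyridin-4-yl (a 2.6-fold higher number from compound 3 to compound 4 (0.42 log units; beyond the scatter)) and against pyridin-2-yl (a 2.9-fold higher number from compound 1 to compound 4 (0.47 log units; beyond the scatter)), so at this amine nitrogen, compounds 1 and 3 each give a lower number than compounds 2 and 4. Nothing measured here accounts for this gap.

The compounds shown leave open where an unsubstituted phenyl ring or pyridin-3-yl would fall on this read-out. They also leave open whether a phenyl ring carrying methoxy or a nitrile in place of the halogen would stay with compounds 2 and 4.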